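A Stereocentre Flip on the Aminocyclohexyl Amide

The source may report more compounds than this note shows. Statements on the series, on what has been measured and on what is new or still open speak of the compounds shown alone.

Three compounds sharing one core were measured in an assay for inhibition of MAP/microtubule affinity-regulating kinase 3 (Homo sapiens), read by HTRF, with a stated time of 2 h; on this read-out higher numbers stand for weaker inhibition and lower numbers for stronger inhibition. Compound 1 `CCNC(=O)c1cc(-c2cnn3cc(-c4cnn(C)c4)cnc23)cs1` gives 129 nM. Compound 2 `Cn1cc(-c2cnc3c(-c4csc(C(=O)NC(CO)C5CC5)c4)cnn3c2)cn1` gives 9 nM, a change of a 14-fold lower number from compound 1 to compound 2 (1.16 log units; beyond the scatter). Compound 3 `Cn1cc(-c2cnc3c(-c4csc(C(=O)N[C@@H]5CCCC[C@H]5N)c4)cnn3c2)cn1` gives 1 nM, the lowest number of the three, with a 130-fold lower number from compound 1 to compound 3 (2.11 log units; beyond the scatter) and a 9.0-fold lower number from compound 2 to compound 3 (0.95 log units; beyond the scatter). Compound 4 `Cn1cc(-c2cnc3c(-c4csc(C(=O)N[C@@H]5CCCC[C@@H]5N)c4)cnn3c2)cn1` has not been measured; compared with compound 3, (the two compounds have the same atoms and bonds and differ only in configuration as drawn: 1 of 2 stereo elements differ; a stereocentre at a saturated ring carbon is drawn R in compound 3 and S in compound 4). Among the measured compounds shown here, none of the measured steps changes a stereocentre, so they do not bear directly on this change; they show only that the amide substituent matters strongly in this assay. A modest step is therefore expected, a 3.0-fold higher number from compound 3 to compound 4 (0.48 log units; beyond the scatter), most likely towards a higher number. Compound 4 is estimated at 3 nM, within 0.5 nM to 30 nM.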

Compound 4, half-maximal inhibitory concentration in the MAP/microtubule affinity-regulating kinase 3 assay: <= 0.5 nM
Compound 4: a limit, no number (the forecaster's own chance of this, stated with the estimate: 2%); middle value at least 6.0-fold (0.77 log units) from the limit.
By their numbers in the MAP/microtubule affinity-regulating kinase 3 assay, from the lowest: compound 3; then compound 2; then compound 1. At a limit, below all of these: compound 4.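

In the MAP/microtubule affinity-regulating kinase 3 assay compound 4 stands at a limit, not a number: <= 0.5 nM. Changing one stereocentre on the 2-aminocyclohexyl group gives in the MAP/microtubule affinity-regulating kinase 3 assay an at least 2.0-fold lower number from compound 3 to compound 4 (0.30 log units; that floor lies within the scatter), so this flip costs no inhibition, and the 2-aminocyclohexyl amide keeps its lead with an at least 18-fold lower number from compound 2 to compound 4 (1.25 log units; beyond the scatter) and an at least 250-fold lower number from compound 1 to compound 4 (2.41 log units; beyond the scatter). In a physicochemical assay for solubility, at pH 7 (a lower number here means a less soluble compound, a higher number a more soluble compound), compound 3 gives 193000 nM and compound 4 gives 68000 nM. Configuration at this carbon does register in the physicochemical assay: the measured solubility of compound 3, 193000 nM, and of compound 4, 68000 nM, a 2.8-fold lower number (0.45 log units; beyond the scatter)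

From the compounds shown here alone, how far compound 4 lies past its limit stays open. So does whether a carboxylic acid in place of the amine on the cyclohexyl ring would keep this inhibition.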